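Swapping a methyl for a pyridin-2-yl on the piperazine

The compounds below may be only part of what the source reports. "The series", "measured", "known", "first", "only" and "open" are said of these compounds alone.

Of the compounds shown here, three sharing one core have been measured in an ADME assay on Vero cells (Chlorocebus sabaeus) for antiproliferative activity, read by MTT assay; on this read-out lower numbers stand for stronger inhibition and higher numbers for weaker inhibition. Compound 1 `c1ccc2c(c1)ccn2-c1nc(N2CCCCC2)nc2ccccc12` gives 50 ug/mL. Compound 2 `CN1CCN(c2nc(-n3ccc4ccccc43)c3ccccc3n2)CC1` differs from compound 1 only in the ring attached to the core. Compound 2 gives 22.3 ug/mL; that is the step of a 2.2-fold lower number from compound 1 to compound 2 (0.35 log units; beyond the scatter). Compound 3 `COc1ccc(-c2nc(N3CCN(C)CC3)nc3ccccc23)c(OC)c1`, carrying a different group on the core, gives 50 ug/mL. Among these three numbers compound 2 stands lowest, with compound 1 and compound 3 both above it.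

The next compound is compound 4 `c1ccc(N2CCN(c3nc(-n4ccc5ccccc54)c4ccccc4n3)CC2)nc1`. Compared with compound 2 the change is pyridin-2-yl in place of methyl on an amine nitrogen in a ring. Among the compounds with values here, the only measured step, from compound 1 to compound 2, concerns the ring on the aromatic carbon of the core, not the group on the amine nitrogen of that ring, so it does not speak directly to this change. Within the data shown here, no measured pair varies the substituent on that nitrogen. With nothing to point either way, the expectation is for no step beyond the scatter in this assay, that is an expected step of a 1.0-fold lower number from compound 2 to compound 4 (0.01 log units; within the scatter).

Compound 4 is therefore estimated at 22 ug/mL, within a range from 10 ug/mL to 50 ug/mL.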

Compound 4, half-maximal inhibitory concentration: 50 ug/mL
For compound 4 the middle estimate is 2.3-fold (0.36 log units) below the measured one; the range from low to high includes it.
By their numbers in this assay, from the lowest: compound 2; then compounds 1, 3 and 4 (each within the scatter of the next).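

The amine nitrogen of the piperazine proves to be a position that responds in this assay: when the single carbon of methyl gives way to pyridin-2-yl, an aromatic ring with one hetero atom, the result is a 2.2-fold higher number from compound 2 to compound 4 (0.35 log units; beyond the scatter), a modest step. Read with a 2.2-fold lower number from compound 1 to compound 2 (0.35 log units; beyond the scatter), this shows that the lower number of compound 2 does not survive either of two separate changes, one replacing its methylpiperazine with piperidin-1-yl and the other replacing only the methyl with pyridin-2-yl. Nothing available explains why the number rises at this nitrogen.

This single step cannot separate the effect of adding a ring from that of the ring nitrogen within pyridin-2-yl, and a plain phenyl, a short ethyl chain or a bare amine hydrogen at the same nitrogen would help to tell these apart. On these data alone, it also remains open whether pyridin-2-yl would have a similar effect alongside the different group on the core of compound 3, since this one step comes from a single pair of compounds.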